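The source may hold more compounds than are shown below. What is called first, only, known or untested is meant among the compounds shown, and "the series" means these compounds.

Compound 1 `CN1CC[C@@H](N(c2cc(C#CC(C)(C)C)sc2C(=O)O)C(=O)[C@H]2CC[C@H](C)CC2)C1=O`: 22.5 mL/min/kg
Compound 2 `CN1CC[C@H](N(c2cc(C#CC(C)(C)C)sc2C(=O)O)C(=O)[C@H]2CC[C@H](C)CC2)C1=O`: 73.7 mL/min/kg

Among the compounds with values here, in an ADME assay on the whole organism (Rattus norvegicus, strain Sprague-Dawley) for pharmacokinetics, read by LC-MS, with a stated time of 72 h, at a dose of 1 mg/kg by the intravenous route (on this read-out higher numbers stand for fast clearance and lower numbers for slow clearance), compound 2 stands highest of the two, and a 3.3-fold higher number from compound 1 to compound 2 (0.52 log units; beyond the scatter) is the only measured step. Behind that modest step lies (the fact that compounds 1 and 2 differ only in the configuration as drawn), so it says nothing directly about ring size. Compound 3 `CN1CCCC[C@@H](N(c2cc(C#CC(C)(C)C)sc2C(=O)O)C(=O)[C@H]2CC[C@H](C)CC2)C1=O` carries 1-methyl-2-oxoazepan-3-yl in place of 1-methyl-2-oxopyrrolidin-3-yl on an amide-type nitrogen. A step of similar modest size is therefore expected, tentatively downward, as compound 2 at 73.7 mL/min/kg tops the pair. The expected change is a 1.6-fold lower number from compound 2 to compound 3 (0.21 log units; within the scatter). For compound 3 the estimated clearance is 45 mL/min/kg, with an expected range of 18 mL/min/kg to 110 mL/min/kg.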

Compound 3, clearance: 15.9 mL/min/kg
For compound 3 the middle estimate is 2.8-fold (0.45 log units) above the measured one, outside the stated range (below it).
By their numbers in this assay, from the lowest: compounds 3 and 1 (each within the scatter of the next); then compound 2.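

Putting 1-methyl-2-oxoazepan-3-yl in place of 1-methyl-2-oxopyrrolidin-3-yl on the amide-type nitrogen gives two readings of clearance: a 4.6-fold lower number from compound 2 to compound 3 (0.67 log units; beyond the scatter), but a 1.4-fold lower number from compound 1 to compound 3 (0.15 log units; within the scatter). The larger ring at this position is thus compatible with low clearance, and the size of the step depends on which drawn form of the five-membered ring serves as the reference. The earlier pair could speak only to configuration, not to ring size: the fact that compounds 1 and 2 differ only in the configuration as drawn.

The compounds shown leave open how the opposite configuration of 1-methyl-2-oxoazepan-3-yl would compare. They also leave open where 1-methyl-2-oxopiperidin-3-yl, or an amine on this ring, would fall.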